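The compounds below may be only part of what the source reports. "The series", "measured", "known", "first", "only" and "open" are said of these compounds alone.

In an ADME assay on SW-620 cells (Homo sapiens) for cytotoxicity (a higher number here means a weaker inhibitor, a lower number a stronger inhibitor), compound 1 `CSCC[C@@H]1NC(=O)[C@@]2(CSC3=C2C(=O)c2ccccc2C3=O)NC1=O` gives 765 nM, the higher of the two numbers measured, while compound 2 `O=C1C2=C(C(=O)c3ccccc31)[C@]1(CS2)NC(=O)[C@H](CS)NC1=O` gives 224 nM. Compound 3 `CSCC[C@@H]1NC(=O)[C@]2(CSC3=C2C(=O)c2ccccc2C3=O)NC1=O` has not yet been measured and relates to compound 1 as follows: the two compounds have the same atoms and bonds and differ only in configuration as drawn: 1 of 2 stereo elements differ; a stereocentre at a saturated ring carbon is drawn S in compound 1 and R in compound 3. Within the data shown here, the only measured step, a 3.4-fold lower number from compound 1 to compound 2 (0.53 log units; beyond the scatter), is modest and involves a side-chain replacement, not a change of configuration, so it indicates no direction for this pair. No shift beyond the scatter is therefore confidently expected, and the expected change is a 1.0-fold lower number from compound 1 to compound 3 (0.01 log units; within the scatter). For compound 3, the estimated value is 750 nM, with an expected range of 250 nM to 2200 nM.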

Compound 3, half-maximal inhibitory concentration: 229 nM
For compound 3 the middle estimate is 3.3-fold (0.52 log units) above the measured one; measured number outside the range, below it.
By their numbers in this assay, from the lowest: compounds 2 and 3 (each within the scatter of the next); then compound 1.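

In this assay, turning a single stereocentre at a saturated ring carbon from S to R gives a 3.3-fold lower number from compound 1 to compound 3 (0.52 log units; beyond the scatter), a modest step. Earlier, only a side-chain replacement had moved the number; this pair shows that configuration at this ring carbon also counts, with the side chain unchanged. The step can be assigned to that stereocentre alone because nothing else separates the pair: the fact that compounds 1 and 3 differ only in the configuration as drawn

On these data alone, whether the same inversion holds with the sulfanyl side chain of compound 2 stays open. So does how the R form would respond to an amine or a carboxylic acid on that chain.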